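Methyl for chloro in a cytotoxicity series

The source may report more compounds than this note shows. Statements on the series, on what has been measured and on what is new or still open speak of the compounds shown alone.

Compound 1 `CN1CCN(CCNCc2cn(-c3ccc(F)cc3F)nc2-c2cccc(Cl)c2)CC1`: 15000 nM
Compound 2 `Cc1ccccc1-c1nn(Cc2ccccc2)cc1CNCCN1CCN(C)CC1`: > 20000 nM

Of the compounds shown here, two have been measured in an ADME assay on Huh-7 cells (Homo sapiens) for cytotoxicity; a higher number here means that more compound is tolerated, a lower number that less compound is tolerated. Going by the values given here, compound 1 `CN1CCN(CCNCc2cn(-c3ccc(F)cc3F)nc2-c2cccc(Cl)c2)CC1` gives 15000 nM, which is the only number that stands among the results so far. Compound 2 `Cc1ccccc1-c1nn(Cc2ccccc2)cc1CNCCN1CCN(C)CC1` gives > 20000 nM, and this value is a limit of the assay rather than a number. So compound 1 stands as the single numerical point, with the one other result being a limit; the evidence on the measured side is thin, reducing to the limit of > 20000 nM in this assay, at which 1 of the 2 values shown sits.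

Compound 3 `Cc1cccc(-c2nn(-c3ccc(F)cc3F)cc2CNCCN2CCN(C)CC2)c1` is not yet measured. It differs from compound 1 by methyl in place of chloro on an aromatic carbon, on an aromatic carbon of a six-membered aromatic ring of carbon only. Among the compounds with values here, no step between measured compounds exists to guide the reading of this change. Swapping one single heavy atom for another of the same size, with no ring and no donor or acceptor gained or lost, gives no ground for expecting a step beyond the scatter in this assay, in either direction. Compound 3 is therefore estimated at 17000 nM, within a range of 7000 nM to 40000 nM. The step from compound 1 to compound 3 that this estimate means, a 1.1-fold higher number from compound 1 to compound 3 (0.05 log units; within the scatter), is expected to sit inside the scatter.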

Compound 3, half-maximal cytotoxic concentration: > 20000 nM
Compound 3 was reported as a limit; the forecaster's own chance of this, stated with the estimate: 35%; at least 1.1-fold (0.07 log units) between middle value and limit.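

In this assay, going by these compounds alone, the change from 3-chlorophenyl to 3-methylphenyl gives the first step that can be read, and it is an at least 1.3-fold higher number from compound 1 to compound 3 (0.12 log units; that floor lies within the scatter). Compound 3 gives > 20000 nM, which is a limit of the assay and not a number. For this position, on an aromatic carbon meta to a large group, the result fixes only a floor for the step that stays inside the scatter, and how far the step reaches cannot be told, because the results now gather at the limit: the limit of > 20000 nM in this assay, at which 2 of the 3 values shown sit.

The compounds shown leave open how other groups at this position would read, such as methoxy, an amine or a carboxylic acid, and whether any of them would give a step beyond the scatter. They also leave open whether methyl in place of chloro would read the same way on another core, since compound 2 differs from compound 1 and compound 3 in more than one place and offers no comparison.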